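The compounds below may be only part of what the source reports. "The series", "measured", "known", "first", "only" and "open" are said of these compounds alone.

Measured so far, in an in vitro functional assay on 1321-N1 cells for agonist activity at P2Y purinoceptor 2 (Homo sapiens), read by scintillation proximity assay and inositol phosphate accumulation; a lower number here means that less compound is needed, a higher number that more compound is needed for the effect:
- compound 1 `CCSc1nc(=O)ccn1[C@@H]1O[C@H](COP(=O)(O)O)[C@@H](O)[C@H]1O`: 1500 nM
- compound 2 `O=c1ccn([C@@H]2O[C@H](COP(=O)(O)O)[C@@H](O)[C@H]2O)c(SCCc2ccccc2)n1`: 1300 nM

Compound 2 and compound 1 lie within the scatter of each other, as the step of a 1.2-fold lower number from compound 1 to compound 2 (0.06 log units; within the scatter) shows; nothing separates them. Among the compounds with values here, compound 3 `CSc1nc(=O)ccn1[C@@H]1O[C@H](COP(=O)(O)O)[C@@H](O)[C@H]1O` differs from compound 2 by hydrogen in place of benzyl on a saturated chain carbon bound to a sulfur, the only step bearing on it being the one from compound 1 to compound 2, which stayed within the scatter although it likewise altered the chain on the sulfur. Compound 3 is therefore expected to show no step beyond the scatter in this assay , a 1.3-fold higher number from compound 2 to compound 3 (0.12 log units; within the scatter), and its value is estimated at 1700 nM, within 700 nM to 4000 nM.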

Compound 3, half-maximal effective concentration: 2900 nM
Compound 3: middle estimate off by 1.7-fold (0.23 log units), on the low side; low and high end bracket the measured number.
By their numbers in this assay, from the lowest: compounds 2, 1 and 3 (each within the scatter of the next, the first and the last beyond it).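

In this assay the chain on the sulfur does register: going from phenethyl to methyl gives a 2.2-fold higher number from compound 2 to compound 3 (0.35 log units; beyond the scatter), a modest step and the only one here beyond the scatter. Hydrogen in place of methyl stays within the scatter, at a 1.9-fold higher number from compound 1 to compound 3 (0.29 log units; within the scatter), so only the two ends of the series separate, and compound 1 cannot be told from either. Nothing available accounts for this step.

Still open, on these data alone, is whether the phenyl or the chain length carries the step. A longer chain without phenyl, or an amine or carboxylic acid on the chain, could test this.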